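The source may hold more compounds than are shown below. What is called first, only, known or untested is meant among the compounds shown, and "the series" means these compounds.

Of the compounds shown here, three sharing one core have been tested in a functional assay on MGC-803 cells (Homo sapiens) for cytotoxicity, read by MTT assay, with a stated time of 72 h; on this read-out lower numbers stand for stronger inhibition and higher numbers for weaker inhibition. Compound 1 (`CN(C)c1ccc(C=C2C(=O)N(c3ccc(Cl)cc3)N(c3ccc(Cl)cc3)C2=O)cc1`) gives 80200 nM, compound 2 (`O=C1C(=Cc2ccc(Cl)cc2)C(=O)N(c2ccc(Cl)cc2)N1c1ccc(Cl)cc1`) gives 32600 nM, and compound 3 (`COc1cc(C=C2C(=O)N(c3ccc(Cl)cc3)N(c3ccc(Cl)cc3)C2=O)ccc1O`) gives 21800 nM. Compound 3 therefore stands at the low end of this small set, but not alone, since the data show a 1.5-fold lower number from compound 2 to compound 3 (0.17 log units; within the scatter). Compound 1 is clearly separated from it, with a 3.7-fold lower number from compound 1 to compound 3 (0.57 log units; beyond the scatter).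

The next compound, compound 4 (`COc1ccc(C=C2C(=O)N(c3ccc(Cl)cc3)N(c3ccc(Cl)cc3)C2=O)cc1`), carries 4-methoxyphenyl in place of 4-hydroxy-3-methoxyphenyl on a double-bonded chain carbon bound to a double-bonded ring carbon. Within the data shown here, no measured step isolates this exchange. The closest evidence comes from the steps that alter the group at this same place. These are the two steps above and a 2.5-fold lower number from compound 1 to compound 2 (0.39 log units; beyond the scatter), and all of them are modest or lie within the scatter. Compound 4 is thus expected to fall in the same range as compound 2 and compound 3, with any shift more likely towards a higher number. The expected change, a 1.5-fold higher number from compound 3 to compound 4 (0.17 log units; within the scatter), is not expected to lie clearly beyond the scatter. For compound 4 the estimated value in this assay is 32000 nM, with an expected range from 14000 nM to 75000 nM.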

Compound 4, half-maximal inhibitory concentration: > 128000 nM
Compound 4 gave a limit, no number; the forecaster's own chance of this, stated with the estimate: 5%; middle value at least 4.0-fold (0.60 log units) away from the limit.
By their numbers in this assay, from the lowest: compounds 3 and 2 (each within the scatter of the next); then compound 1. At a limit, above all of these: compound 4.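

Compound 4 gives no number in this assay, only a limit: the limit of > 128000 nM in this assay, at which 1 of the 4 values shown sits. Among the first three compounds, changes to the group on the double-bonded chain carbon bound to a double-bonded ring carbon were modest or within the scatter, but this position now proves able to carry a larger loss: 4-methoxyphenyl in place of 4-hydroxy-3-methoxyphenyl gives an at least 5.8-fold higher number from compound 3 to compound 4 (0.76 log units; beyond the scatter), and methoxy in place of chloro on an aromatic carbon gives an at least 3.9-fold higher number from compound 2 to compound 4 (0.59 log units; beyond the scatter). The absence of the hydroxy does not by itself sort the series, since compound 2, whose 4-chlorophenyl also has no hydroxy, gives 32600 nM, while swapping out dimethylamino gives an at least 1.5-fold higher number from compound 1 to compound 4 (0.20 log units; that floor lies within the scatter), so that exchange shows no clear separation.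

As far as these compounds go, it remains open whether the hydroxy or the methoxy of the 4-hydroxy-3-methoxyphenyl group accounts for the gap, and how far the true value lies past the limit. From the compounds shown here alone, how a carboxylic acid or a primary amine on the same aromatic ring would read in this assay also stays open.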